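Swapping the group on a thiocarbonyl carbon

A few compounds are considered here, and "the series" means these few. Any claim that something is new, unique, unknown or untested is made for them only; others in the source may bear on it.

Compound 1 `CC(C)NC(=S)N/N=C1\CC(c2ccc(O)cc2)Oc2cc(O)ccc21`: 68100 nM
Compound 2 `Oc1ccc(C2C/C(=N\NC(=S)N3CCOCC3)c3ccc(O)cc3O2)cc1`: 76300 nM
Compound 3 `CC(C)(C)NC(=S)N/N=C1\CC(c2ccc(O)cc2)Oc2cc(O)ccc21`: 50000 nM

In a functional assay on HeLa cells (Homo sapiens) for cytotoxicity, read by MTT assay, with a stated time of 72 h (on this read-out lower numbers stand for stronger inhibition and higher numbers for weaker inhibition), compound 3 stands level with compound 1 and compound 2: a 1.4-fold lower number from compound 1 to compound 3 (0.13 log units; within the scatter), and a 1.5-fold lower number from compound 2 to compound 3 (0.18 log units; within the scatter). The next structure, compound 4 `Oc1ccc(C2C/C(=N\NC(=S)N3CCCC3)c3ccc(O)cc3O2)cc1`, has pyrrolidin-1-yl in place of (tert-butyl)amino on a thiocarbonyl carbon. The closest guide is the change at that same carbon from compound 1 to compound 2, which also brings in a ring: a 1.1-fold higher number from compound 1 to compound 2 (0.05 log units; within the scatter). The step to compound 3 from compound 2 changes that carbon too. Neither step left the scatter, so no step beyond the scatter is expected in this assay. The estimated move is a 1.2-fold higher number from compound 3 to compound 4 (0.08 log units; within the scatter). Compound 4 is expected at 60000 nM, with an estimated range of 32000 nM to 110000 nM.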

Compound 4, half-maximal inhibitory concentration: 65200 nM
Beside the measured number, compound 4's estimate is 1.1-fold (0.04 log units) below it; low and high end bracket the measured number.
By their numbers in this assay, from the lowest: compounds 3, 4, 1 and 2 (each within the scatter of the next).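

In this assay, pyrrolidin-1-yl, a ring with no hydrogen-bond donor, stays within the scatter of the open-chain (tert-butyl)amino group (a 1.3-fold higher number from compound 3 to compound 4 (0.12 log units; within the scatter)) and of isopropylamino (a 1.0-fold lower number from compound 1 to compound 4 (0.02 log units; within the scatter)). It also stays within the scatter of the other ring, morpholin-4-yl (a 1.2-fold lower number from compound 2 to compound 4 (0.07 log units; within the scatter)), so all four groups on this thiocarbonyl carbon now read alike. Nothing available explains this flat result.

From the compounds shown here alone, whether any group here can move the number beyond the scatter stays open. A phenylamino group, a longer chain such as octylamino, or a carboxylic acid on the chain would test that.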